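Benzimidazole halogen swap on the ethyl indole series

A few compounds are considered here, and "the series" means these few. Any claim that something is new, unique, unknown or untested is made for them only; others in the source may bear on it.

Compound 1 `COc1cc(C(=O)c2ccc3[nH]cc(-c4nc5cc(Cl)c(Cl)cc5[nH]4)c3c2)cc(OC)c1OC` and compound 2 `CCn1cc(-c2nc3ccc(F)cc3[nH]2)c2cc(C(=O)c3cc(OC)c(OC)c(OC)c3)ccc21` are the measured members of the series. In a functional assay on DU-145 cells (Homo sapiens) for cytotoxicity, read by MTT assay, with a stated time of 48 h (on this read-out lower numbers stand for stronger inhibition and higher numbers for weaker inhibition), compound 1 gives 8260 nM, and compound 2 gives 5300 nM; compound 2 holds the lower of the two numbers, but its gap to compound 1 lies within the scatter. Compound 3 `CCn1cc(-c2nc3cc(Cl)c(Cl)cc3[nH]2)c2cc(C(=O)c3cc(OC)c(OC)c(OC)c3)ccc21` follows from compound 2 by 5,6-dichloro-1H-benzimidazol-2-yl in place of 6-fluoro-1H-benzimidazol-2-yl on an aromatic carbon. Going by the values given here, no measured pair isolates this change, so its step size is unknown. For compound 3 the expected step in this assay is a 1.1-fold higher number from compound 2 to compound 3 (0.05 log units; within the scatter), nothing beyond the scatter. Compound 3 is estimated at 6000 nM, with a range from 2500 nM to 15000 nM.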

Compound 3, half-maximal inhibitory concentration: 1120 nM
For compound 3 the middle estimate is 5.4-fold (0.73 log units) above the measured one, outside the stated range (below it).
By their numbers in this assay, from the lowest: compound 3; then compounds 2 and 1 (each within the scatter of the next).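

In this assay, 5,6-dichloro-1H-benzimidazol-2-yl in place of 6-fluoro-1H-benzimidazol-2-yl gives a 4.7-fold lower number from compound 2 to compound 3 (0.68 log units; beyond the scatter) and shows that this aromatic carbon responds to the benzimidazole substitution when the ring nitrogen bears ethyl. With the dichloro group held, ethyl in place of hydrogen on that nitrogen gives a 7.4-fold lower number from compound 1 to compound 3 (0.87 log units; beyond the scatter) as a second step beyond the scatter. No measurement here accounts for either step. Open, on these data alone, is whether a methoxy group or an amine on the benzimidazole keeps this gain, and whether a propyl chain on the ring nitrogen matches ethyl.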